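Replacing a phenol with a chlorophenyl in compound 3

This account rests on a few compounds, and the source may have more. Where it says the series, first, only, none or still open, it means among the compounds named here.

Compound 2 `COc1cc(/C=C/C(=O)C(=Cc2cn(-c3ccccc3)nc2-c2ccccc2O)C(=O)/C=C/c2ccc(O)c(OC)c2)ccc1O` was examined in a functional assay on MCF7 cells (Homo sapiens) for antiproliferative activity, read by MTT assay, with a stated time of 24 h, tested at 0.1 ug/mL (on this read-out lower numbers stand for a stronger effect and higher numbers for a weaker effect at the one concentration tested), where compound 2 gives 91%. Going by the values given here, only one other number stands beside it: compound 1 `O=Cc1cn(-c2ccccc2)nc1-c1cccc([N+](=O)[O-])c1`, which in this assay gives 86%, and the two readings lie within the scatter of each other, so no order between them can be read. Compound 3 `COc1cc(/C=C/C(=O)C(=Cc2cn(-c3ccccc3)nc2-c2ccc(Cl)cc2)C(=O)/C=C/c2ccc(O)c(OC)c2)ccc1O` has not yet been measured. It differs from compound 2 in one place: 4-chlorophenyl in place of 2-hydroxyphenyl on an aromatic carbon. Among the compounds with values here, no step between measured compounds is available to guide the expectation, so the step of a number 3 percentage points lower from compound 2 to compound 3 (within the scatter) is expected to stay within the scatter. Compound 3 is therefore estimated to give 88% in this assay, between 74% and 100%.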

Compound 3, a percentage reported as activity, at one concentration (the size of the read-out at that concentration, not a potency): 72%
Compound 3: middle estimate off by 16 percentage points, on the high side; measured number below the stated range.
By their numbers in this assay, from the lowest: compound 3; then compounds 1 and 2 (each within the scatter of the next).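

In this assay, putting 4-chlorophenyl in place of 2-hydroxyphenyl gives a number 19 percentage points lower from compound 2 to compound 3 (beyond the scatter), which shows that this aromatic carbon of the five-membered ring is not indifferent to the group it carries. Because the exchange alters both the substituent and its place on the phenyl ring, this single step cannot assign the stronger effect to either alteration. Nothing available explains the change. The compounds shown leave open how 2-chlorophenyl or 4-hydroxyphenyl would read at this carbon, which would separate the two alterations. They also leave open whether an aminophenyl would follow either compound.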